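The compounds below may be only part of what the source reports. "The series", "measured", "known", "first", "only" and "open" are said of these compounds alone.

Measured so far:
- Compound 1, `CC1(C)N=C(N)N=C(N)N1c1ccc(Cl)c(CCc2ccc(S(=O)(=O)F)cc2)c1`: 5.82
- Compound 2, `CC1(C)N=C(N)N=C(N)N1c1ccc(Cl)c(OCCOc2ccc(S(=O)(=O)F)cc2)c1`: 7.27

The numbers come from an assay on isolated protein for inhibition of Dihydrofolate reductase (Mus musculus); on this read-out lower numbers stand for lower potency and higher numbers for higher potency (the scale is a negative logarithm). Of the two measured compounds, compound 1 gives the lower number, 5.82, and compound 2 gives 7.27; the gap between them lies beyond the scatter of this assay. Among the compounds with values here, no step between compounds that differ in one place is available, so the two values can only be set side by side, not traced to a single change.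

The compound still to be measured is compound 3, `CC1(C)N=C(N)N=C(N)N1c1cccc(CCc2ccc(S(=O)(=O)F)cc2)c1`. It differs from compound 1 in one place, as counted from the two structures:

hydrogen in place of chloro on an aromatic carbon

Within the data shown here, with no measured step to lean on, the expectation for this change rests on compound 1 alone. The chloro is removed and nothing heavier takes its place, so a modest fall in this assay is expected, an estimated step of a number 0.32 log units lower from compound 1 to compound 3 (beyond the scatter). This expected change may also turn out to be no step beyond the scatter. Compound 3 is therefore expected to give about 5.5, within the range 4.9 to 6.1.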

Compound 3, logarithm of the reciprocal of the active concentration, log(1/C): 8.1
For compound 3 the middle estimate is 2.60 log units below the measured one, and the stated range ends below it.
By their numbers in this assay, from the lowest: compound 1; then compound 2; then compound 3.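

In this assay hydrogen in place of chloro on this aromatic carbon, which stands ortho to a large group and para to a large group, gives a number 2.28 log units higher from compound 1 to compound 3 (beyond the scatter) and so runs upward, with the loss of one heavy atom going along with a large gain in the number. Both earlier compounds carried the chloro, so they could say nothing about its part; compound 3 shows that, on the core of compound 1, the chloro is not needed for a high number and that its presence goes along with a much lower one. Nothing measured here explains why the step is so large or why it runs in this direction.

The compounds shown leave open whether the same change would give a step of similar size on the chain of compound 2, since only the chain of compound 1 is seen both with and without the chloro. They also leave open whether fluoro, methyl or methoxy on this aromatic carbon would give a number closer to that of hydrogen or to that of chloro.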